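This account rests on a few compounds, and the source may have more. Where it says the series, first, only, none or still open, it means among the compounds named here.

Measured so far:
- compound 1 `CC(C)(C)C(=O)N1N=CCC1c1cocn1` gives 1560 nM in an ADME assay on the whole organism (Rattus norvegicus) for pharmacokinetics, at a dose of 2 mg/kg by the oral route; a higher number here means more compound in the circulation at the dose given, a lower number less compound in the circulation
- compound 2 `Cc1nnc(N2CCC(C(=O)N3N=CC[C@H]3c3cc(F)cc(F)c3)CC2)o1` gives 2930 nM in this assay
- compound 3 `CC(C)(C)C(=O)N1N=CCC1c1cccnc1` gives 1560 nM in this assay

Compound 2 stands level with compounds 1 and 3: the gaps to both lie within the usual scatter, so no order among the three can be read from these numbers. Compound 4 `N#Cc1cc(N2CCC(C(=O)N3N=CC[C@H]3c3cc(F)cc(F)c3)CC2)ncn1` is not yet measured. It differs from compound 2 by a group of 8 heavy atoms (5 carbon, 3 nitrogen; one six-membered aromatic ring with 2 hetero atoms) in place of a group of 6 heavy atoms (3 carbon, 2 nitrogen, 1 oxygen; one five-membered aromatic ring with 3 hetero atoms), on an amine nitrogen in a ring. Within the data shown here, no pair of measured compounds shares this change, and the three measured compounds give no lead on what it does. The step from compound 2 to compound 4 in this assay is therefore expected to be small, a 1.3-fold lower number from compound 2 to compound 4 (0.12 log units; within the scatter), with no clear direction beyond the scatter. For compound 4 the estimate in this assay is 2200 nM, within a range of 700 nM to 7000 nM.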

Compound 4, maximal plasma concentration: 542 nM
Compound 4: middle estimate off by 4.1-fold (0.61 log units), on the high side, and the stated range ends above it.
By their numbers in this assay, from the lowest: compound 4; then compounds 1, 3 and 2 (each within the scatter of the next).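

In this assay, the group on the amine nitrogen in a ring clearly matters: replacing 5-methyl-1,3,4-oxadiazol-2-yl with the nitrile-bearing six-membered aromatic ring gives a 5.4-fold lower number from compound 2 to compound 4 (0.73 log units; beyond the scatter). The two groups have the same counts of hydrogen-bond donors and acceptors and no net charge, so these counts do not separate them. Nothing measured here gives a cause for this step.

The compounds shown cannot separate the part played by the nitrile from that of the six-membered aromatic ring. From the compounds shown here alone, how an acetyl group or a plain phenyl ring on the same nitrogen would stand in this assay remains open.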